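A few compounds are considered here, and "the series" means these few. Any claim that something is new, unique, unknown or untested is made for them only; others in the source may bear on it.

Compound 1 (`O=C1c2ccc(OCc3cccc(-c4ccc(C(F)(F)F)cc4F)c3)cc2CN1C1CCCC1`) offers no starting number: in an ADME assay on microsomes from liver (Rattus norvegicus) for metabolic stability, read by LC-MS, with a stated time of 1 h, at 37 degrees C, tested at 4 uM (a lower number here means that less of the compound is left, a higher number that more of the compound is left), compound 1 is recorded as "not determined" (no result reported). Compound 3 (`Cc1ccc(C(=O)O)cc1-c1cccc(COc2ccc3c(c2)CN(C2CCCC2)C3=O)c1`) is the next structure to be read in this assay. The change is 5-carboxy-2-methylphenyl in place of 2-fluoro-4-(trifluoromethyl)phenyl on an aromatic carbon, meta to a large group. Among the compounds with values here, the only measured reference is compound 2 (`CC(C)CCn1sc2cc(OCc3cccc(-c4ccc(Cl)c(C(=O)O)c4)c3)ccc2c1=O`), which has a different core but also carries a carboxy group, and compound 2 gives 92%. With no number for compound 1, the size and direction of the step from it cannot be read from the data. Within the data shown here, compound 3 is instead expected to stay high on the scale, level with compound 2 or moderately lower, since only that single reading supports the expectation. For compound 3 the estimated value is 80%, with an expected range of 60% to 95%.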

Compound 3, percent of the compound remaining: 2%
For compound 3 the middle estimate is 78 percentage points above the measured one, and the stated range ends above it.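

No new step can be read for compound 3: compound 1 has no single number in this assay and compound 2 differs from it in more than one place. Open remains what 5-carboxy-2-methylphenyl in place of 2-fluoro-4-(trifluoromethyl)phenyl does alone. No evidence bears on this result.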